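Notes on the step from compound 2 to compound 3

The source may report more compounds than this note shows. Statements on the series, on what has been measured and on what is new or still open speak of the compounds shown alone.

Measured in an in vivo ADME assay on the whole organism (Rattus norvegicus) (a higher number here means that more of the compound sits outside the plasma, a lower number that more of the compound stays in the plasma), for these compounds
compound 1 `NS(=O)(=O)c1ccccc1-c1ccc(C(=O)NCCC(=O)Nc2ccc(Br)cn2)cc1` (5.4 L/kg)
compound 2 `NS(=O)(=O)c1ccccc1-c1ccc(C(=O)NC(CC(=O)Nc2ccc(Br)cn2)C(=O)O)cc1` (0.6 L/kg)

Compound 2 holds the lower of the two numbers (0.6 L/kg). Compound 3 `NS(=O)(=O)c1ccccc1-c1ccc(C(=O)NC(CC(=O)Nc2ccc(Br)cn2)C(=O)N2CCCCC2)cc1` differs from it by piperidin-1-yl in place of hydroxy on a carbonyl carbon. Among the compounds with values here, the one measured step bearing on this is a 9.0-fold lower number from compound 1 to compound 2 (0.95 log units; beyond the scatter), beyond the scatter, where the carboxy entered. Within the data shown here, compound 3 no longer carries that carboxy, so a partial return toward compound 1 (5.4 L/kg) is expected, though no measured compound carries this amide. The expected change is a 4.2-fold higher number from compound 2 to compound 3 (0.62 log units; beyond the scatter), a higher number. Compound 3 is estimated at 2.5 L/kg (range 1 L/kg to 6 L/kg).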

Compound 3, volume of distribution: 5.9 L/kg
Compound 3: the middle estimate sits 2.4-fold (0.37 log units) below what was measured; the range from low to high includes it.
By their numbers in this assay, from the lowest: compound 2; then compounds 1 and 3 (each within the scatter of the next).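

In this assay, piperidin-1-yl in place of hydroxy on the carbonyl carbon gives a 9.8-fold higher number from compound 2 to compound 3 (0.99 log units; beyond the scatter) and so removes the drop seen with the carboxy. With a 1.1-fold higher number from compound 1 to compound 3 (0.04 log units; within the scatter) and within the scatter, the (piperidin-1-yl)carbonyl on this saturated chain carbon leaves the number level with hydrogen, so a substituent here does not in itself bring the low number of compound 2. Nothing at hand gives a reason for this difference between carboxy and (piperidin-1-yl)carbonyl.

Open, from the compounds shown here alone, is whether a primary amide, a methyl ester or a dimethylamide on this carbonyl carbon reads like compound 2 or like compound 3. Also open, going by these compounds, is whether a carboxy on a longer chain at this carbon gives a drop of the same size.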